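The compounds below may be only part of what the source reports. "The series", "measured", "known", "first", "only" and "open" are said of these compounds alone.

Compound 1 `CCCCc1cn(C(c2ccccc2)c2cc3cc(Br)ccc3nc2OC)nn1` is one of three measured compounds that share a core and differ only in the group on the five-membered aromatic ring with three nitrogen. In an ADME assay on HeLa cells (Homo sapiens) for cytotoxicity, read by sulforhodamine B assay, with a stated time of 48 h, tested at 10 uM (on this read-out higher numbers stand for more inhibition at the one concentration tested (going by the name of the read-out) and lower numbers for less inhibition), compound 1 gives -2.87%, the lowest of the three numbers. Compound 2 `CCCCCCCc1cn(C(c2ccccc2)c2cc3cc(Br)ccc3nc2OC)nn1` gives 9.7%, and compound 3 `COc1nc2ccc(Br)cc2cc1C(c1ccccc1)n1cc(-c2ccc(F)cc2)nn1` gives 4.27%. The step of a number 12.6 percentage points higher from compound 1 to compound 2 (beyond the scatter) is the only one beyond the scatter, while the step of a number 7.1 percentage points higher from compound 1 to compound 3 (within the scatter) stays within it. Compound 4 `COc1nc2ccc(Br)cc2cc1C(c1ccccc1)n1cc(-c2ccccc2C(F)(F)F)nn1` has not been measured; it differs from compound 1 by 2-(trifluoromethyl)phenyl in place of butyl on an aromatic carbon. The closest guide is 4-fluorophenyl in place of butyl, and because a number 7.1 percentage points higher from compound 1 to compound 3 (within the scatter) stayed within the scatter, only a small step is expected for compound 4, a number 5.9 percentage points higher from compound 1 to compound 4 (within the scatter). Compound 4 is therefore estimated at 3%, with a range from -8% to 14%.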

Compound 4, a percentage reported as inhibition, at one concentration (the size of the read-out at that concentration, not a potency): -1.3%
The estimate for compound 4 lay 4.3 percentage points above the measured number, and the stated range covers the measured number.
By their numbers in this assay, from the lowest: compounds 1, 4, 3 and 2 (each within the scatter of the next, the first and the last beyond it).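

In this assay, placing 2-(trifluoromethyl)phenyl on this aromatic carbon gives a step within the scatter against butyl, a number 1.6 percentage points higher from compound 1 to compound 4 (within the scatter), and against 4-fluorophenyl, a number 5.6 percentage points lower from compound 3 to compound 4 (within the scatter). A step beyond the scatter appears against heptyl, a number 11 percentage points lower from compound 2 to compound 4 (beyond the scatter), yet compound 3 stays within the scatter of compound 2. Nothing available explains these numbers. As far as these compounds go, it remains open whether a group of another kind at this position, such as an amine or a carboxylic acid, would give a larger step.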